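Swapping the amide heteroaryl ring: pyrimidine to methylimidazole

A few compounds are considered here, and "the series" means these few. Any claim that something is new, unique, unknown or untested is made for them only; others in the source may bear on it.

Measured compounds:
compound 1 `COc1ccc(C(=O)Nc2cc(Nc3nc(-c4cn(C)c5ccccc45)c4cccnc4n3)c(OC)cc2N(C)CCN(C)C)nc1`: 4230 nM
compound 2 `COc1cc(N(C)CCN(C)C)c(NC(=O)c2ccncn2)cc1Nc1nc(-c2cn(C)c3ccccc23)c2cccnc2n1`: 4520 nM

In a functional assay on A549 cells (Homo sapiens) for antiproliferative activity, read by MTT assay, with a stated time of 72 h (on this read-out higher numbers stand for weaker inhibition and lower numbers for stronger inhibition), compound 2 gives 4520 nM, and compound 1 gives 4230 nM. These two numbers lie within the scatter of each other, as the step of a 1.1-fold higher number from compound 1 to compound 2 (0.03 log units; within the scatter) shows, so compound 2 cannot be set apart from compound 1 on this read-out.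

Compound 3 `COc1cc(N(C)CCN(C)C)c(NC(=O)c2nccn2C)cc1Nc1nc(-c2cn(C)c3ccccc23)c2cccnc2n1` carries the change (1-methyl-1H-imidazol-2-yl in place of pyrimidin-4-yl on a carbonyl carbon). Within the data shown here, the only measured step that bears on it is the exchange of one aromatic ring for another on the same carbonyl carbon, a 1.1-fold higher number from compound 1 to compound 2 (0.03 log units; within the scatter), which stayed within the scatter. On that basis no step beyond the scatter is expected in this assay from compound 2 to compound 3, and the expected step of a 1.0-fold lower number from compound 2 to compound 3 (0.00 log units; within the scatter) is essentially flat. Among the measured compounds shown here, compound 3 is therefore estimated at 4500 nM, with a range from 2000 nM to 10000 nM, resting on the single comparison available.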

Compound 3, half-maximal inhibitory concentration: 5640 nM
Compound 3: middle estimate off by 1.3-fold (0.10 log units), on the low side, and the stated range covers the measured number.
By their numbers in this assay, from the lowest: compounds 1, 2 and 3 (each within the scatter of the next).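

The earlier pair exchanged one six-membered aromatic ring for another on the carbonyl carbon, whereas this change brings in a five-membered aromatic ring, 1-methyl-1H-imidazol-2-yl, with the same counts of heavy atoms, hetero atoms and hydrogen-bond acceptors as the pyrimidin-4-yl it replaces. In this assay the numbers show a 1.2-fold higher number from compound 2 to compound 3 (0.10 log units; within the scatter) and, against the methoxy-substituted pyridine, a 1.3-fold higher number from compound 1 to compound 3 (0.12 log units; within the scatter) so across these three compounds neither the change of ring size nor the added N-methyl group moves the number beyond the scatter, and compounds 1, 2 and 3 cannot be set apart on this read-out. Nothing available gives a reason for this flat result, and no measurement of any property of these rings accompanies it.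

What the compounds shown leave open is whether this position stays as flat once the aromatic heterocycle gives way to something of another kind, such as a plain phenyl ring, a saturated piperidine, a longer alkyl chain, or a group carrying a primary amine or a carboxylic acid. From the compounds shown here alone, all three rings here hold two hetero atoms or a pyridine nitrogen, so it also remains open how a ring with no hetero atom at all would read in this assay on the same core.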